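Two Aminothiophene Ketones at Baseline, a Third Awaiting Measurement

This account rests on a few compounds, and the source may have more. Where it says the series, first, only, none or still open, it means among the compounds named here.

Compound 1 `CC(C)Cc1csc(N)c1C(=O)c1ccc(Cl)cc1`: 1%
Compound 2 `CC(C)(C)Cc1c(-c2ccoc2)sc(N)c1C(=O)c1ccc(Cl)cc1`: 1%

In an assay on CHO cells for displacement of a labelled ligand from adenosine receptor A3 (Homo sapiens), read by scintillation counting, tested at 10 uM (a lower number here means less inhibition, a higher number more inhibition at the concentration tested (going by the name of the read-out)), compound 1 gives 1%. In this assay compound 2 gives 1%, which is level with compound 1 at the digits shown; the two values lie within the scatter of each other, so nothing can be said about one sitting above the other. Neither compound shows more than a trace of inhibition at the concentration tested.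

Compound 3 `CC(C)(C)Cc1c(-c2ccc(F)cc2F)sc(N)c1C(=O)c1ccc(Cl)cc1` differs from compound 2 only in one place on the shared core: 2,4-difluorophenyl in place of furan-3-yl on an aromatic carbon. Within the data shown here, no step between measured compounds is available that would show what such a change does here. Since both measured compounds stand at the same low level, the expectation for compound 3 rests only on that level, and the step from compound 2 to compound 3 in this assay is expected to be a number 2 percentage points higher from compound 2 to compound 3 (within the scatter), that is, none beyond the scatter. Compound 3 is therefore estimated to give 3% in this assay, with a range from -8% to 18%.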

Compound 3, a percentage reported as inhibition, at one concentration (the size of the read-out at that concentration, not a potency): 1%
Estimate against measurement, compound 3: 2 percentage points above, and the stated range covers the measured number.
By their numbers in this assay, from the lowest: compounds 1, 2 and 3 (each within the scatter of the next).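

In this assay, among these compounds, the exchange of furan-3-yl for 2,4-difluorophenyl on the aromatic carbon next to the ring sulfur gives the first single-place step at this position, and it reads no change at the digits printed from compound 2 to compound 3 (within the scatter). A five-membered aromatic ring with 1 hetero atom gives way to a six-membered aromatic ring of carbon only, 5 heavy atoms become 8, and the hydrogen-bond acceptor of the furan-3-yl group is gone, yet none of this moves the read-out beyond the scatter. The step lies entirely at the low end of the read-out, so it shows that this one exchange brings no measurable inhibition at the concentration tested, and no evidence bears on why that is so.

The compounds shown leave open whether any other group on this carbon, such as an amine, a carboxylic acid or a longer alkyl chain, would lift the read-out clear of this level. They also leave open whether a change in the neopentyl group next to this position, made with either aromatic group in place, would do so.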